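Swapping the methoxy for a chloro on the shared core

The compounds below may be only part of what the source reports. "The series", "measured", "known", "first", "only" and "open" are said of these compounds alone.

Three measured compounds share one core and differ only in the group on one aromatic ring. Compound 1 `COc1cccc(N2CCN(C(=O)C(C)N3C(=O)CCC3=O)CC2)c1` carries a methoxy, compound 2 `CC(C(=O)N1CCN(c2cccc(F)c2)CC1)N1C(=O)CCC1=O` a fluoro, and compound 3 `CC(C(=O)N1CCN(c2cccc(C(F)(F)F)c2)CC1)N1C(=O)CCC1=O` a trifluoromethyl. In a functional assay on the whole organism (strain Swiss) with Mus musculus as the target, in the maximal electroshock model, with a stated time of 1 h, at a dose of 100 mg/kg by the intraperitoneal route (a higher number here means a stronger effect of the compound at the dose given, a lower number a weaker effect), compound 1 gives 0%. In this assay compound 2 gives 0%, while compound 3 gives 50%. Compound 1 thus stands level with compound 2, the two together being the lowest of the three numbers, and compound 3 lies far above both.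

The measured steps frame what a single change at this place can do. Putting fluoro in place of methoxy gave no change at the digits printed from compound 1 to compound 2 (within the scatter), whereas putting trifluoromethyl in place of methoxy gave a number 50 percentage points higher from compound 1 to compound 3 (beyond the scatter), and between the two smaller groups a number 50 percentage points higher from compound 2 to compound 3 (beyond the scatter).

Compound 4 `CC(C(=O)N1CCN(c2cccc(Cl)c2)CC1)N1C(=O)CCC1=O` is not yet measured. Its change from compound 1 is chloro in place of methoxy on an aromatic carbon. Chloro is neither of the two groups already tried, so both steps from compound 1 bear on it: one showed nothing, the other a large rise. An intermediate step upward is therefore expected, a number 25 percentage points higher from compound 1 to compound 4 (beyond the scatter). For compound 4 the expected value in this assay is 25%, with a range from 0% to 60%.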

Compound 4, a percentage reported as activity, at one dose (the size of the read-out at that dose, not a potency): 50%
Beside the measured number, compound 4's estimate is 25 percentage points below it; measured number inside the range.
By their numbers in this assay, from the lowest: compounds 1 and 2 (each within the scatter of the next); then compounds 3 and 4 (each within the scatter of the next).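

In this assay, among the compounds shown here, chloro in place of methoxy gives a number 50 percentage points higher from compound 1 to compound 4 (beyond the scatter), so trifluoromethyl is not the only group at this place on the aromatic ring that lifts the read-out above that of methoxy. The two halogens also part ways: chloro in place of fluoro gives a number 50 percentage points higher from compound 2 to compound 4 (beyond the scatter), so fluoro and chloro cannot be treated as interchangeable here, while chloro in place of trifluoromethyl gives no change at the digits printed from compound 3 to compound 4 (within the scatter), which leaves the four compounds in just two groups, methoxy with fluoro and chloro with trifluoromethyl. No measurement is available that would explain why the groups divide in this way.

Other groups at this place, such as bromo, methyl, nitrile or an amine, could show whether this split into two groups holds or whether values in between occur. The read-out also comes from one dose and one time, so it leaves open whether compound 3 and compound 4 would stay level at a lower dose, and whether compound 1 and compound 2 would show any effect at a higher one.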